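Nitrophenyl Amide in Place of Pyrazinyl Amide

The source may hold more compounds than are shown below. What is called first, only, known or untested is meant among the compounds shown, and "the series" means these compounds.

Among the measured compounds shown here, compound 2 `O=C(Nc1cccc(Nc2ncc(F)c(Nc3ccc(F)cc3)n2)c1)c1cnccn1` is one of only two compounds known in a functional assay on A549 cells (Homo sapiens) for antiproliferative activity, read by sulforhodamine B assay, with a stated time of 3 days (a lower number here means a stronger inhibitor of growth, a higher number a weaker inhibitor of growth), where compound 2 gives 10300 nM. The other, compound 1 `O=C(c1cccc(Nc2ncc(F)c(Nc3ccc(F)cc3)n2)c1)N1CCCCC1`, gives 13200 nM in this assay, and the step of a 1.3-fold lower number from compound 1 to compound 2 (0.11 log units; within the scatter) separates them. Compound 3 `O=C(Nc1cccc(Nc2ncc(F)c(Nc3ccc(F)cc3)n2)c1)c1cccc([N+](=O)[O-])c1` differs from compound 2 by 3-nitrophenyl in place of pyrazin-2-yl on a carbonyl carbon. For the measured compounds named here, no measured step covers this exchange on the carbonyl carbon; the single step known, also at the amide, stayed within the scatter, so no shift beyond the scatter is expected in this assay. Compound 3 is therefore estimated at 10300 nM, between 5000 nM and 21000 nM, an expected no change at the digits printed from compound 2 to compound 3 (within the scatter).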

Compound 3, concentration for 50% growth inhibition: 7250 nM
Compound 3: the middle estimate sits 1.4-fold (0.15 log units) above what was measured; the range from low to high includes it.
By their numbers in this assay, from the lowest: compounds 3, 2 and 1 (each within the scatter of the next).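

In this assay, 3-nitrophenyl on the carbonyl carbon gives a 1.4-fold lower number from compound 2 to compound 3 (0.15 log units; within the scatter), so an aromatic ring of carbon only, bearing a nitro group, can stand where pyrazin-2-yl stood without a shift beyond the scatter. Both amide changes shown now stay within the scatter. Nothing available bears on the reason for this result. As far as these compounds go, whether an amine or a carboxylic acid in place of the nitro group would move the number beyond the scatter remains open. So does the outcome of replacing the aromatic ring with a longer alkyl chain.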